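A few compounds are considered here, and "the series" means these few. Any claim that something is new, unique, unknown or untested is made for them only; others in the source may bear on it.

In an assay on brain (strain C57BL6) for displacement of a labelled ligand from AP2-associated protein kinase 1 (Mus musculus), read by scintillation counting, with a stated time of 1 h (on this read-out lower numbers stand for stronger inhibition and higher numbers for weaker inhibition), compound 1 `CC(=O)Nc1cc(-c2ccc(OC[C@@H](N)CC(C)C)c(C)c2)ccn1` gives 0.08 nM, while compound 2 `CC(=O)Nc1cc(-c2ccc(OC[C@@H](N)CC(C)C)c(Cl)c2)ccn1` gives 0.06 nM. The two differ by methyl in place of chloro on an aromatic carbon, placed on an aromatic carbon of a six-membered aromatic ring of carbon only, ortho to a (2-amino-4-methylpentyl)oxy group and meta to a large group; that step is a 1.3-fold higher number from compound 2 to compound 1 (0.12 log units; within the scatter). Compound 3 `Cc1cc(-c2cc(Cl)c(OC[C@@](C)(N)CC(C)C)cn2)ccn1` rests on another core, and the difference between the two cores is not broken down here. In this assay compound 3 gives 0.7 nM, clearly apart from both compound 1 and compound 2. Compound 4 `Cc1cc(-c2cc(C)c(OC[C@@](C)(N)CC(C)C)cn2)ccn1` has not yet been measured. It arises from compound 3 by methyl in place of chloro on an aromatic carbon, the same kind of change as before, though here the site is an aromatic carbon of a six-membered aromatic ring with 1 nitrogen, ortho to a group of 9 heavy atoms, meta to a 2-methylpyridin-4-yl group and opposite the ring nitrogen. Because the earlier step was a 1.3-fold higher number from compound 2 to compound 1 (0.12 log units; within the scatter), only a small step is expected, about a 1.1-fold higher number from compound 3 to compound 4 (0.06 log units; within the scatter). Compound 4 is therefore estimated at 0.8 nM, with a likely range from 0.4 nM to 1.8 nM.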

Compound 4, inhibition constant: 4.7 nM
The estimate for compound 4 lay 5.9-fold (0.77 log units) below the measured number, outside the stated range (above it).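

In this assay, methyl in place of chloro on an aromatic carbon gives a 6.7-fold higher number from compound 3 to compound 4 (0.83 log units; beyond the scatter), so the change costs clearly more on this core than it did on the core of compound 1. The size of the step therefore does not carry over between these two cores: the same change on two cores in this assay, a 1.3-fold higher number (0.12 log units; within the scatter) from compound 2 to compound 1 and a 6.7-fold higher number (0.83 log units; beyond the scatter) from compound 3 to compound 4, 5.0-fold (0.70 log units) apart, beyond the scatter of two such steps. This shows that, for this change, a step measured on one core cannot simply be transferred to the other, but two pairs cannot show which feature of the cores sets the difference, nor how the change would behave on any further core.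

What the compounds shown leave open is which of the differences between the two cores goes with the larger step. As far as these compounds go, it also remains open whether fluoro, methoxy or a nitrile on that aromatic carbon, ortho to the group of 9 heavy atoms, would track chloro or methyl on either core.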